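Lengthening the Amide Substituent a Second Time

The source may report more compounds than this note shows. Statements on the series, on what has been measured and on what is new or still open speak of the compounds shown alone.

Among the compounds with values here, compound 2, `CCCCOc1cc(C(=O)NCC)nn1-c1ccccc1`, gives 0% in a functional assay on the whole organism (strain Wistar) for inhibition, with Rattus norvegicus as the target, read by paw edema, with stated times of 30 min and 3 h, at a dose of 100 mg/kg by the oral route (a lower number here means less inhibition, a higher number more inhibition at the dose given (going by the name of the read-out)), the lowest of the two numbers known so far. Within the data shown here, its only neighbour, compound 1, `CCCCOc1cc(C(=O)NC)nn1-c1ccccc1`, gives 65% in this assay. The step of a number 65 percentage points lower from compound 1 to compound 2 (beyond the scatter) shows that methyl in place of hydrogen at this spot removed nearly all inhibition. Compound 3, `C=CCNC(=O)c1cc(OCCCC)n(-c2ccccc2)n1`, carries the next change, (vinyl in place of methyl on a saturated chain carbon bound to an amide-type nitrogen), so ethylcarbamoyl becomes allylcarbamoyl. Among the measured compounds shown here, only that one measured step bears on this change; it was large and downward, and compound 2 already sits at the floor, leaving little room to fall. The expected step is a number 5 percentage points higher from compound 2 to compound 3 (within the scatter), and compound 3 is therefore estimated at 5%, within 0% to 25%.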

Compound 3, a percentage reported as inhibition, in the whole organism at one dose (the size of the read-out at that dose, not a potency): 4.4%
Compound 3: the middle estimate sits 0.6 percentage points above what was measured, within the range that was stated.
By their numbers in this assay, from the lowest: compounds 2 and 3 (each within the scatter of the next); then compound 1.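

In this assay, allyl in place of ethyl gives a number 4.4 percentage points higher from compound 2 to compound 3 (within the scatter), so adding the double bond changes nothing that can be told from the scatter. The comparison with the methyl amide gives a number 60.6 percentage points lower from compound 1 to compound 3 (beyond the scatter), which shows that the loss seen with ethyl also holds for allyl, a second group on this chain carbon. No measurement here explains this drop. Open, as far as these compounds go, is whether a longer chain, a cyclopropyl ring or a hydroxyethyl group on the amide nitrogen would stay as low, and whether the unsubstituted amide would keep the inhibition of compound 1.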